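Extending the Methyl of Compound 1 to Pentyl

A few compounds are considered here, and "the series" means these few. Any claim that something is new, unique, unknown or untested is made for them only; others in the source may bear on it.

Compound 1, `Cc1cc2ccccc2nc1-c1cn(CCC(F)(F)C(F)(F)C(F)(F)C(F)(F)C(F)(F)C(F)(F)C(F)(F)C(F)(F)F)nn1`, was tested in a functional assay on THP-1 cells (Homo sapiens) for cytotoxicity, read by MTT assay, with a stated time of 24 h; on this read-out lower numbers stand for stronger inhibition and higher numbers for weaker inhibition. In this assay compound 1 gave only a limit, > 100 ug/mL, and no number. Compound 2, `Cc1cc2ccccc2nc1-c1cn(-c2ccc(F)cc2)nn1`, was also run in this assay, and compound 2 likewise gave a limit, > 100 ug/mL. Compound 3, `CCCCCCCCCCn1cc(-c2nc3ccccc3cc2CC)nn1`, differs from the other two at more than one place; in this assay compound 3 gave 34.3 ug/mL. For the measured compounds named here, two of the three results therefore sit at the limit of > 100 ug/mL in this assay, at which 2 of the 3 values shown sit, and compound 1 stands at that limit rather than at a number, so no measured step can be placed around it.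

Compound 4, `CCCCCc1cc2ccccc2nc1-c1cn(CCC(F)(F)C(F)(F)C(F)(F)C(F)(F)C(F)(F)C(F)(F)C(F)(F)C(F)(F)F)nn1`, carries a single change from compound 1: butyl in place of hydrogen on a saturated chain carbon bound to an aromatic carbon. Going by the values given here, no pair of measured compounds shows this change, so its size is open. The account expects a move toward stronger inhibition, beyond the usual scatter, for the step of an at least 1.6-fold lower number from compound 1 to compound 4 (0.22 log units; that floor lies within the scatter), while holding the uncertainty wide. For compound 4 in this assay the expected value is 60 ug/mL, with a range from 25 ug/mL to 150 ug/mL.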

Compound 4, half-maximal inhibitory concentration: > 100 ug/mL
Compound 4: only a limit was reported; the forecaster's own chance of this, stated with the estimate: 40%; middle value at least 1.6-fold (0.22 log units) away from the limit.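

In this assay compound 4 gave > 100 ug/mL, which is a limit and not a number. For the compounds shown here, compound 1 also stands at a limit, so no step between compound 1 and compound 4 can be read. The compounds shown leave open whether pentyl in place of methyl changes the read-out at all: the limit of > 100 ug/mL in this assay, at which 3 of the 4 values shown sit.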